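A few compounds are considered here, and "the series" means these few. Any claim that something is new, unique, unknown or untested is made for them only; others in the source may bear on it.

Compound 1, with the structure `Cc1ccccc1OCCCCCn1ccc(=O)[nH]c1=O`, is the reference point of this account. In an ADME assay on HEL cells (Homo sapiens) for cytotoxicity (a lower number here means that less compound is tolerated, a higher number that more compound is tolerated), compound 1 reaches only a limit of the assay, > 100000 nM, so no single number stands behind it. Two further compounds belong to the same set: compound 2, `O=c1ccn(CCCCOc2ccc(Br)cc2)c(=O)[nH]1`, and compound 3, `O=c1ccn(CCCCCOc2ccc(Cl)cc2)c(=O)[nH]1`. In this assay compound 2 is recorded as "not determined" (no result reported), and in this assay compound 3 is recorded as "not determined" (no result reported). Thus, of the three entries, only one carries any figure at all, and that one is the limit of > 100000 nM in this assay, at which 1 of the 3 values shown sits; no step between two measured compounds can be drawn from this set.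

The compound still to be measured is compound 4, `Cc1ccc(OCCCCCn2ccc(=O)[nH]c2=O)cc1`. It differs from compound 1 in one place: 4-methylphenyl in place of 2-methylphenyl on an oxygen on a saturated carbon. The two compounds share the same atoms, joined differently, and the shared core of compound 1 is untouched.

For the measured compounds named here, with no measured step to lean on, the author expects the change from compound 1 to compound 4 in this assay to bring no shift beyond the usual scatter, and expects compound 4 most likely to sit again at the limit of the assay. The expected step is a step that the limit leaves unreadable from compound 1 to compound 4. Compound 4 is estimated at 150000 nM, within a range from 50000 nM to 500000 nM.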

Compound 4, half-maximal cytotoxic concentration: > 100000 nM
Compound 4 gave a limit, no number; the forecaster's own chance of this, stated with the estimate: 80%; the middle value is on the limit's open side.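

Compound 1 and compound 4 both stop at a limit in this assay, so no step between them can be read: the limit of > 100000 nM in this assay, at which 2 of the 4 values shown sit.

The compounds shown leave open whether 4-methylphenyl in place of 2-methylphenyl shifts the half-maximal cytotoxic concentration at all, and where any of these compounds would stand as a single number.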